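Three values and one large exchange on the shared core

This account rests on a few compounds, and the source may have more. Where it says the series, first, only, none or still open, it means among the compounds named here.

Values measured in a functional assay on MCF7 cells (Homo sapiens) for antiproliferative activity, read by MTT assay, with stated times of 24 h and 72 h; on this read-out higher numbers stand for weaker inhibition and lower numbers for stronger inhibition:
- compound 1 `COc1cc(N2C(=O)[C@@H](Oc3ccccc3)[C@H]2c2ccc(Br)cc2)cc(OC)c1OC` gives 48000 nM
- compound 2 `COc1cc(N2C(=O)[C@@H](Oc3ccccc3)[C@H]2c2ccc(C#N)cc2)cc(OC)c1OC` gives 31600 nM
- compound 3 `COc1cc(N2C(=O)[C@@H](Oc3ccccc3)[C@H]2c2ccc(N=[N+]=[N-])cc2)cc(OC)c1OC` gives 23000 nM

Compound 3 shares the low end of this short range with compound 2, and two steps fix its place. These are a 1.4-fold lower number from compound 2 to compound 3 (0.14 log units; within the scatter) and a 2.1-fold lower number from compound 1 to compound 3 (0.32 log units; beyond the scatter). The remaining step is a 1.5-fold lower number from compound 1 to compound 2 (0.18 log units; within the scatter).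

Compound 4 `COc1ccc([C@@H]2[C@H](Oc3ccccc3)C(=O)N2c2cc(OC)c(OC)c(OC)c2)c([N+](=O)[O-])c1O` is not yet measured in this assay. In it, the 4-azidophenyl group on a saturated ring carbon is replaced entirely: a group of 12 heavy atoms (7 carbon, 1 nitrogen, 4 oxygen; one six-membered aromatic ring of carbon only) in place of a group of 9 heavy atoms (6 carbon, 3 nitrogen; one six-membered aromatic ring of carbon only), on a saturated ring carbon. The measured steps bear on this only loosely, as each swaps one substituent on an aromatic carbon, with cyano, azido or bromo exchanged, and all of them are small. Going by the values given here, no measured step covers an exchange of this size, so they set no limit on it. With compound 3 at 23000 nM, the values lie high enough to leave more room downward, so a lower number is expected, though with wide uncertainty. The expected change is a 7.7-fold lower number from compound 3 to compound 4 (0.88 log units; beyond the scatter). Compound 4 is estimated at 3000 nM, within an expected range of 200 nM to 40000 nM.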

Compound 4, half-maximal inhibitory concentration: 89000 nM
For compound 4 the middle estimate is 30-fold (1.47 log units) below the measured one; the whole stated range lies below it.
By their numbers in this assay, from the lowest: compounds 3, 2, 1 and 4 (each within the scatter of the next, the first and the last beyond it).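

The earlier steps shown here only swapped a single substituent on the aromatic ring, whereas exchanging the whole group on this saturated ring carbon moves the number upward in this assay, with a 3.9-fold higher number from compound 3 to compound 4 (0.59 log units; beyond the scatter) and a 2.8-fold higher number from compound 2 to compound 4 (0.45 log units; beyond the scatter). The same exchange leaves compound 4 level with the bromo compound, as a 1.9-fold higher number from compound 1 to compound 4 (0.27 log units; within the scatter) shows, so at this position the larger group with its added hydrogen-bond donor and acceptors brought no gain over any of the three earlier groups. No measurement shown here accounts for this result.

The compounds shown cannot separate which part of the entering group goes with the higher number, as that group differs from the others in several features at once. They also leave open how an amine or a carboxylic acid on this aromatic ring would read.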